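The compounds below may be only part of what the source reports. "The series", "measured", "known", "first", "only" and "open" are said of these compounds alone.

Compound 2 `COc1cccc(-c2nc(SCC(=O)c3sc(-c4ccccc4)nc3C)[nH]c(=O)c2C#N)c1` was tested in a functional assay on U-87MG ATCC cells for antiproliferative activity against U-87 MG (Homo sapiens), read by MTT assay, with a stated time of 48 h, tested at 5 uM (a higher number here means a weaker effect of the compound at the concentration tested, a lower number a stronger effect), and gave 99%. Its only companion, compound 1 `COc1ccc(-c2nc(C)c(C(=O)CSc3nc(-c4ccc(Cl)cc4)c(C#N)c(=O)[nH]3)s2)cc1`, gave 102% in this assay, a number that lies within the scatter of compound 2, so neither compound can be ranked against the other; both read as having no effect at the concentration used.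

Compound 3 `COc1ccc(-c2nc(SCC(=O)c3sc(-c4ccccc4)nc3C)[nH]c(=O)c2C#N)cc1OC` departs from compound 2 by methoxy in place of hydrogen on an aromatic carbon. Going by the values given here, no step between measured compounds is known, so nothing in the numbers speaks for a shift beyond the scatter in either direction. Compound 3 is therefore expected to give 96% in this assay, between 80% and 108%, a step of a number 3 percentage points lower from compound 2 to compound 3 (within the scatter) that is estimated to stay within the scatter.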

Compound 3, a percentage reported as activity, at one concentration (the size of the read-out at that concentration, not a potency): 80.8%
Estimate against measurement, compound 3: 15.2 percentage points above, within the range that was stated.
By their numbers in this assay, from the lowest: compound 3; then compounds 2 and 1 (each within the scatter of the next).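

Going from 3-methoxyphenyl to 3,4-dimethoxyphenyl brings a number 18.2 percentage points lower from compound 2 to compound 3 (beyond the scatter) in this assay and gives the first difference beyond the scatter among these compounds. This aromatic carbon, ortho to a methoxy group and para to a large group, is therefore a place where a change goes with a stronger effect at the concentration tested. No measurement shown accounts for this step.

Going by these compounds, whether an amine or a hydroxy group on the same carbon would act alike stays open. So does whether the added methoxy would do the same without the methoxy group already present.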